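This account rests on a few compounds, and the source may have more. Where it says the series, first, only, none or still open, it means among the compounds named here.

Of the compounds shown here, three sharing one core have been measured in an ADME assay on liver for metabolic stability, with Liver microsome (Homo sapiens) as the target, using microsomes; on this read-out lower numbers stand for slow clearance and higher numbers for fast clearance. Compound 1 `O=C(Nc1cc(-c2ccccn2)n[nH]1)N1CCC(c2cccc(F)c2)CC1` gives 25.3 mL.min-1.g-1, compound 2 `O=C(Nc1cc(-c2ccccn2)n[nH]1)N1CCC(c2ccc(F)cc2)CC1` gives 42.5 mL.min-1.g-1, and compound 3 `O=C(Nc1cc(-c2ccccn2)n[nH]1)N1CCC(Oc2ccccc2)CC1` gives 27.3 mL.min-1.g-1, so compound 3 stands within the usual scatter of both others. Compound 4 `O=C(Nc1cc(-c2ccccn2)n[nH]1)N1CCC(c2ccccc2)CC1` carries phenyl in place of phenoxy on a saturated ring carbon. The closest measured changes are at the same place: phenoxy in place of 3-fluorophenyl gave a 1.1-fold higher number from compound 1 to compound 3 (0.03 log units; within the scatter), phenoxy in place of 4-fluorophenyl gave a 1.6-fold lower number from compound 2 to compound 3 (0.19 log units; within the scatter), and 4-fluorophenyl in place of 3-fluorophenyl gave a 1.7-fold higher number from compound 1 to compound 2 (0.23 log units; within the scatter). With all three inside the scatter, no real shift is expected in this assay. The estimated change is a 1.1-fold higher number from compound 3 to compound 4 (0.04 log units; within the scatter). For compound 4 the expected value is 30 mL.min-1.g-1, with an estimated range of 15 mL.min-1.g-1 to 60 mL.min-1.g-1.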

Compound 4, intrinsic clearance in microsomes: 15.3 mL.min-1.g-1
Beside the measured number, compound 4's estimate is 2.0-fold (0.29 log units) above it; the range from low to high includes it.
By their numbers in this assay, from the lowest: compounds 4, 1, 3 and 2 (each within the scatter of the next, the first and the last beyond it).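

In this assay, going by these compounds alone, hydrogen in place of fluoro gives a 2.8-fold lower number from compound 2 to compound 4 (0.44 log units; beyond the scatter) and is the only new step beyond the scatter, whereas the same swap gives a 1.7-fold lower number from compound 1 to compound 4 (0.22 log units; within the scatter) and stays within it. Phenyl in place of phenoxy gives a 1.8-fold lower number from compound 3 to compound 4 (0.25 log units; within the scatter) and also stays within it, so the result separates compound 4 only from the 4-fluorophenyl group of compound 2. Nothing available explains the difference between the two fluoro steps. Still open, as far as these compounds go, is how an amine or a carboxylic acid on this saturated ring carbon would read, and how a chloro or methoxy group on the phenyl ring would compare with fluoro.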